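Anilino variation on a bromophenyl pyrrolinone core

The source may report more compounds than this note shows. Statements on the series, on what has been measured and on what is new or still open speak of the compounds shown alone.

Measured compounds:
compound 1 `O=C(C1=C(O)C(=O)N(CCCn2ccnc2)C1c1ccc(Br)cc1)c1ccccc1`: "not active" (no number reported)
compound 2 `O=C(C1=C(Nc2ccc(OC(F)(F)F)cc2)C(=O)N(CCCn2ccnc2)C1c1ccc(Br)cc1)c1ccccc1`: 11500 nM

Of the compounds shown here, two of this core have been measured. In a functional assay on U2OS cells (Homo sapiens) for antiproliferative activity, read by MTT assay, with a stated time of 72 h (on this read-out higher numbers stand for weaker inhibition and lower numbers for stronger inhibition), compound 1 is reported only as "not active" (no number reported), and no number is given for it. Among the compounds with values here, compound 2 is therefore the only compound with a numerical result, giving 11500 nM in this assay; it stands alone, and no step between measured compounds can be read from these two entries.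

Compound 3 `O=C(C1=C(Nc2ccccc2Br)C(=O)N(CCCn2ccnc2)C1c1ccc(Br)cc1)c1ccccc1` has not been measured. It differs from compound 2 in one place: 2-bromophenyl in place of 4-(trifluoromethoxy)phenyl on an amine nitrogen. The amine nitrogen and all other parts of the molecule are kept.

Within the data shown here, since no measured pair shows what such a change on the amine nitrogen does in this assay, there is no basis for expecting a step in either direction beyond the usual scatter. Compound 3 is therefore expected to stay close to compound 2, with the estimated step of a 1.0-fold higher number from compound 2 to compound 3 (0.02 log units; within the scatter) lying within the scatter. Compound 3 is estimated at 12000 nM in this assay, with a range from 4000 nM to 40000 nM.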

Compound 3, half-maximal inhibitory concentration: 16900 nM
Compound 3: middle estimate off by 1.4-fold (0.15 log units), on the low side; the range from low to high includes it.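

In this assay, within the data shown here, the exchange of 4-(trifluoromethoxy)phenyl for 2-bromophenyl on the amine nitrogen gives the first step that can be read at this position, a 1.5-fold higher number from compound 2 to compound 3 (0.17 log units; within the scatter). These two aryl groups therefore cannot be told apart on this read-out, even though the entering group has fewer heavy atoms, carries bromine where the leaving group carries oxygen and fluorine, and has no hydrogen-bond acceptor where the leaving group has one. Nothing measured here explains this result.

Among these compounds, compound 1 is reported as "not active" (no number reported), so no step from it to either of the other two compounds can be read, and the comparison between its hydroxyl and the aryl-substituted amine nitrogen stays open. Also open, on these data alone, is whether a carboxylic acid or a dimethylamino group on the phenyl ring, or a morpholine in place of the whole (2-bromophenyl)amino group, would move the number in this assay beyond the scatter.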